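A Nitro Group Added to Compound 1

The source may hold more compounds than are shown below. What is called first, only, known or untested is meant among the compounds shown, and "the series" means these compounds.

Within the data shown here, compound 1 (`O=C(OCc1cn(-c2ccccc2)nn1)[C@@H]1CCCN1`) gives 780000 nM in an ADME assay on THP-1 cells (Homo sapiens) for cytotoxicity, read by MTT assay, with a stated time of 24 h (a higher number here means a weaker inhibitor, a lower number a stronger inhibitor), and so holds the higher of the two numbers measured so far. Compound 2 (`COc1ccc(-n2cc(COC(=O)[C@@H]3CCCN3)nn2)cc1`) gives 218000 nM in this assay and differs by methoxy in place of hydrogen on an aromatic carbon. That single measured step (a 3.6-fold lower number from compound 1 to compound 2 (0.55 log units; beyond the scatter)) is modest but lies beyond the scatter.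

Compound 3 (`O=C(OCc1cn(-c2ccc([N+](=O)[O-])cc2)nn1)[C@@H]1CCCN1`) has not yet been measured. Its change from compound 1 is nitro in place of hydrogen on an aromatic carbon, para to a large group (nitro in place of hydrogen on an aromatic carbon).

Among the measured compounds shown here, the methoxy step is the only measured evidence bearing on this change. Nitro is a different group from methoxy. That step offers only a loose guide to direction and size. A modest step toward a lower number is therefore expected in this assay, although it may not clear the scatter. The estimated step (a 2.2-fold lower number from compound 1 to compound 3 (0.35 log units; beyond the scatter)) is expected to be no larger than the methoxy step. For compound 3 the estimated value is 350000 nM within an expected range (120000 nM to 850000 nM) that stays wide.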

Compound 3, half-maximal inhibitory concentration: 344000 nM
Compound 3: middle estimate off by 1.0-fold (0.01 log units), on the high side, within the range that was stated.
By their numbers in this assay, from the lowest: compounds 2 and 3 (each within the scatter of the next); then compound 1.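

In this assay, nitro in place of hydrogen on the aromatic carbon gives a 2.3-fold lower number from compound 1 to compound 3 (0.36 log units; beyond the scatter), so the lower number seen with methoxy at this kind of site is not confined to that one group. The two substituted compounds cannot be told apart, for nitro in place of methoxy gives a 1.6-fold higher number from compound 2 to compound 3 (0.20 log units; within the scatter), and the exchange of one group for the other makes no readable difference in this pair, while each of the two stands beyond the scatter from compound 1. Nothing available here explains why two such different groups give results so close together.

Going by these compounds, whether any group in place of hydrogen at this site gives a step of similar size remains open, and a carboxylic acid, an amine, a chlorine atom or a longer chain would each test that in a different way. Also open, on these data alone, is whether nitro and methoxy would give the same result on another carbon of the aromatic ring, or whether the step seen here holds only for the site they occupy in compound 2 and compound 3.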